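Moving the hydroxy on the aryl of a proline inhibitor

The source may report more compounds than this note shows. Statements on the series, on what has been measured and on what is new or still open speak of the compounds shown alone.

Compound 1 `O=C(NCC(=O)N1[C@@H](c2ccccc2)CC[C@H]1C(=O)O)[C@@H](S)Cc1ccc(O)cc1` and compound 2 `O=C(NCC(=O)N1[C@@H](c2ccccc2O)CC[C@H]1C(=O)O)[C@@H](S)Cc1ccc(O)cc1` share one core and differ only in that compound 2 carries a hydroxy in place of hydrogen on an aromatic carbon. In an assay on isolated protein for inhibition of Neprilysin (Oryctolagus cuniculus) (a higher number here means a weaker inhibitor, a lower number a stronger inhibitor), compound 1 gives 3.4 nM, and in this assay compound 2 gives 3.5 nM. The step of a 1.0-fold higher number from compound 1 to compound 2 (0.01 log units; within the scatter) is within the scatter, and compound 2 stands highest of the two numbers, with compound 1 its nearest neighbour at a gap inside the scatter. Compound 3 `O=C(NCC(=O)N1[C@@H](c2ccc(O)cc2)CC[C@H]1C(=O)O)[C@@H](S)Cc1ccc(O)cc1` is the next relative: 4-hydroxyphenyl in place of 2-hydroxyphenyl on a saturated ring carbon. Within the data shown here, the only step that bears on it, a 1.0-fold higher number from compound 1 to compound 2 (0.01 log units; within the scatter), shows that a hydroxy on this aryl leaves the number unchanged, so a shift of that hydroxy is expected to give no step beyond the scatter in this assay. Compound 3 is therefore expected at 3.5 nM, estimated to lie between 1.6 nM and 7.5 nM, a step of no change at the digits printed from compound 2 to compound 3 (within the scatter).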

Compound 3, half-maximal inhibitory concentration: 6.36 nM
Compound 3: middle estimate off by 1.8-fold (0.26 log units), on the low side; the range from low to high includes it.
By their numbers in this assay, from the lowest: compounds 1, 2 and 3 (each within the scatter of the next).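

In this assay the shift of the hydroxy gives a 1.8-fold higher number from compound 2 to compound 3 (0.26 log units; within the scatter) and so leaves 2-hydroxyphenyl and 4-hydroxyphenyl on this saturated ring carbon indistinguishable. Adding the hydroxy in the second placement gives a 1.9-fold higher number from compound 1 to compound 3 (0.27 log units; within the scatter) and thus also stays inside the scatter, a result the earlier step had shown only for 2-hydroxyphenyl. Nothing available here speaks to the reason for these numbers.

From the compounds shown here alone, the three compounds cover only a hydroxy or a hydrogen on this aryl, so it remains open whether an amine, a carboxylic acid or a longer chain on the same ring would also leave the number within the scatter. Going by these compounds, it also remains open whether the same tolerance would hold with the aryl replaced by a saturated cyclohexyl group.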